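The source may report more compounds than this note shows. Statements on the series, on what has been measured and on what is new or still open speak of the compounds shown alone.

Compound 1 `Cc1cccc(CSc2nc3cc(NC(=O)C4CC4)ccc3n2C(C)C)c1` is tested in an assay on isolated protein for inhibition of Gonadotropin-releasing hormone receptor (Homo sapiens) (on this read-out higher numbers stand for weaker inhibition and lower numbers for stronger inhibition), where compound 1 gives 6500 nM. Compound 2 `COc1ccccc1CSc1nc2cc(NC(=O)C3CC3)ccc2n1C(C)C` carries a 2-methoxyphenyl in place of the 3-methylphenyl on the saturated chain carbon bound to sulfur, and in this assay compound 2 gives 2100 nM. That single change amounts to a 3.1-fold lower number from compound 1 to compound 2 (0.49 log units; beyond the scatter). Going by the values given here, of the two numbers measured so far, compound 2 therefore stands lowest, with compound 1 as its only neighbour.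

Compound 3 `CC(C)n1c(SCc2ccccc2Cl)nc2cc(NC(=O)C3CC3)ccc21` has not yet been measured. It differs from compound 2 by chloro in place of methoxy on an aromatic carbon. Among the compounds with values here, the one measured step does bear on the same ring, but it moved a group to a different place on that ring while also changing its kind, so it does not test a swap of one ortho group for another. Within the data shown here, it shows only that a change on this ring can shift the number modestly. Among the measured compounds shown here, with no closer precedent, compound 3 is expected to come in at 2500 nM, with a range from 800 nM to 8000 nM. The step this estimate implies is a 1.2-fold higher number from compound 2 to compound 3 (0.08 log units; within the scatter), which is expected to stay within the usual scatter.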

Compound 3, half-maximal inhibitory concentration: 6300 nM
Estimate against measurement, compound 3: 2.5-fold (0.40 log units) below; the range from low to high includes it.
By their numbers in this assay, from the lowest: compound 2; then compounds 3 and 1 (each within the scatter of the next).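

At this place on the ring, ortho to a large group, the kind of group counts in this assay: chloro in place of methoxy gives a 3.0-fold higher number from compound 2 to compound 3 (0.48 log units; beyond the scatter) and so undoes the advantage of compound 2, which means that not just any group here gives the lower number. The 2-chlorophenyl and the 3-methylphenyl, with a 1.0-fold lower number from compound 1 to compound 3 (0.01 log units; within the scatter) between them, cannot be told apart, so among these three compounds only compound 2, with its 2-methoxyphenyl, stands clear of the other two. No supporting measurement is available to say what sets methoxy apart from chloro at this place.

Still open, going by these compounds, is how much of the step from compound 1 to compound 2 comes from the kind of group and how much from its place on the ring, and a methyl at this same place, or a methoxy where compound 1 carries its methyl, would separate the two. On these data alone, it also remains open whether the lower number is particular to methoxy or would extend to a related group here, such as an ethoxy, a hydroxyl or an amine.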